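Branching the acyl chain on a toll-like receptor 8 agonist

A few compounds are considered here, and "the series" means these few. Any claim that something is new, unique, unknown or untested is made for them only; others in the source may bear on it.

Compound 1 `CCCCNc1nc(N)nc2c1CN(C(=O)c1ccccc1)CC2`: 1.4 uM; compound 2 `CCCCNc1nc(N)nc2c1CN(C(=O)CC)CC2`: 0.4 uM.

Both numbers come from an assay on HEK293 cells for agonist activity at Toll-like receptor 8 (Homo sapiens), read by a luciferase reporter, with a stated time of 6 h; a higher number here means that more compound is needed for the effect, a lower number that less compound is needed. Compound 2 shows the lowest number of the two; the nearest is compound 1, and the step of a 3.5-fold lower number from compound 1 to compound 2 (0.54 log units; beyond the scatter) is the only measured one. Compound 3 `CCCCNc1nc(N)nc2c1CN(C(=O)C(C)C)CC2` differs from compound 2 by methyl in place of hydrogen on a saturated chain carbon bound to a carbonyl carbon and a saturated chain carbon. Within the data shown here, no measured step touches this place, so no direction is given by the data; the expected step of a 1.3-fold higher number from compound 2 to compound 3 (0.10 log units; within the scatter) is therefore small, likely within the scatter. Compound 3 is estimated at 0.5 uM, with a range from 0.2 uM to 1.5 uM.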

Compound 3, minimum effective concentration: 1.6 uM
Beside the measured number, compound 3's estimate is 3.2-fold (0.51 log units) below it; measured number above the stated range.
By their numbers in this assay, from the lowest: compound 2; then compounds 1 and 3 (each within the scatter of the next).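

Adding a single methyl to the saturated chain carbon bound to the carbonyl carbon, which turns ethyl into isopropyl, is not a silent change at this position (a 4.0-fold higher number from compound 2 to compound 3 (0.60 log units; beyond the scatter)). Isopropyl and phenyl on the carbonyl carbon cannot be told apart (a 1.1-fold higher number from compound 1 to compound 3 (0.06 log units; within the scatter)), so among these three compounds only the ethyl of compound 2 stands out. No evidence here explains this result. The compounds shown leave open whether acetyl, with a shorter chain, or butanoyl, with a longer unbranched chain, would match or pass compound 2, and how a cyclopropyl on the carbonyl carbon would compare.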